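Second trifluoromethyl on the aryl group of compound 1

The source may report more compounds than this note shows. Statements on the series, on what has been measured and on what is new or still open speak of the compounds shown alone.

Compound 1 `O=C(Nc1cccc(-n2cc(-c3ccncc3)c(-c3ccc(Cl)c(O)c3)n2)c1)Nc1cccc(C(F)(F)F)c1` gives 13800 nM in a functional assay on SK-MEL-5 cells (Homo sapiens) for inhibition, read by sulforhodamine B assay, with a stated time of 48 h (a lower number here means that less compound is tolerated, a higher number that more compound is tolerated), the highest of the three measured values. Compound 2 `O=C(Nc1cccc(-n2cc(-c3ccncc3)c(-c3ccc(Cl)c(O)c3)n2)c1)Nc1ccc(Cl)c(Cl)c1` gives 2350 nM, and compound 3 `COc1cc(-c2nn(-c3cccc(NC(=O)Nc4cccc(C(F)(F)F)c4)c3)cc2-c2ccncc2)ccc1Cl` gives 2680 nM. Both measured changes from compound 1 move the number down beyond the scatter: a 5.9-fold lower number from compound 1 to compound 2 (0.77 log units; beyond the scatter) and a 5.1-fold lower number from compound 1 to compound 3 (0.71 log units; beyond the scatter).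

Compound 4 `O=C(Nc1cccc(-n2cc(-c3ccncc3)c(-c3ccc(Cl)c(O)c3)n2)c1)Nc1cc(C(F)(F)F)cc(C(F)(F)F)c1` differs from compound 1 in one place: trifluoromethyl in place of hydrogen on an aromatic carbon. Within the data shown here, the step that bears most directly on this change is the one from compound 1 to compound 2, since that also alters the aryl group on the amide-type nitrogen, and it gave a 5.9-fold lower number from compound 1 to compound 2 (0.77 log units; beyond the scatter). The change to compound 3 sits elsewhere and is less informative here. Among the measured compounds shown here, no measured step shows a second trifluoromethyl on this aryl group, so the direction is taken from compound 2 alone.

A modest downward step is therefore expected, a 3.1-fold lower number from compound 1 to compound 4 (0.49 log units; beyond the scatter), smaller than the two measured ones. For the measured compounds named here, only a single group is added here. Compound 4 is estimated at 4500 nM, with a range of 1500 nM to 12000 nM.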

Compound 4, concentration lethal to 50% of the cells: 2620 nM
Compound 4: the middle estimate sits 1.7-fold (0.23 log units) above what was measured; the measured number falls inside the stated range.
By their numbers in this assay, from the lowest: compounds 2, 4 and 3 (each within the scatter of the next); then compound 1.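

In this assay a second trifluoromethyl, on an aromatic carbon meta to the first trifluoromethyl group, gives a 5.3-fold lower number from compound 1 to compound 4 (0.72 log units; beyond the scatter) on its own. The aryl group on the urea can therefore carry a change that keeps the original trifluoromethyl and still move the number down beyond the scatter, so this drop does not depend on the chlorine atoms of compound 2. Compound 1 now stands above the other three compounds, with changes at the aryl group and at the oxygen all lowering the number, and no measurement bears on the cause of this drop.

On these data alone, whether a methyl, an amine or a carboxylic acid at this same aromatic carbon would move the number in the same direction remains open. Also open, as far as these compounds go, is whether a second trifluoromethyl and the methyl on the oxygen of compound 3 would combine in one compound.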